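Replacing 2-fluorophenyl with 3-methylphenyl on the shared core

The compounds below may be only part of what the source reports. "The series", "measured", "known", "first", "only" and "open" are said of these compounds alone.

In an ADME assay on BHK-21 cells (Mesocricetus auratus) for cytotoxicity, read by MTT assay, with a stated time of 72 h (on this read-out higher numbers stand for lower toxicity in this test and lower numbers for higher toxicity in this test), compound 1 `NS(=O)(=O)c1ccc(N2N=C(c3ccccc3)CC2c2ccccc2F)cc1` gives 21000 nM. Among the measured compounds shown here, compound 2 `Cc1ccccc1C1CC(c2ccc(OCc3ccccc3)cc2)=NN1c1ccc(S(N)(=O)=O)cc1`, the only other compound measured, gives 20000 nM, and the two numbers lie within the scatter of each other. Compound 3 `Cc1cccc(C2CC(c3ccccc3)=NN2c2ccc(S(N)(=O)=O)cc2)c1` has 3-methylphenyl in place of 2-fluorophenyl on a saturated ring carbon. For the measured compounds named here, no measured pair of compounds differing in one place is available as a guide, so no change beyond the scatter is expected in this assay. The expected step of a 1.1-fold lower number from compound 1 to compound 3 (0.02 log units; within the scatter) stays within the scatter. Compound 3 is estimated at 20000 nM, with an expected range from 9000 nM to 45000 nM.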

Compound 3, half-maximal cytotoxic concentration: 25000 nM
Estimate against measurement, compound 3: 1.3-fold (0.10 log units) below; measured number inside the range.
By their numbers in this assay, from the lowest: compounds 2, 1 and 3 (each within the scatter of the next).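

Among the compounds shown here, the step on a saturated ring carbon, a 1.2-fold higher number from compound 1 to compound 3 (0.08 log units; within the scatter) in this assay, is the first measured at this position, and it lies within the scatter. On the shared core, 3-methylphenyl therefore cannot be told apart from 2-fluorophenyl in this read-out, so this position tolerates this particular exchange without a measurable difference. No supporting measurement is available to explain this result.

As far as these compounds go, it remains open whether a phenyl ring carrying an amine or a carboxylic acid at this position would move the number beyond the scatter.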